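Phenyl in place of furan-3-yl on a methylamino compound

The source may report more compounds than this note shows. Statements on the series, on what has been measured and on what is new or still open speak of the compounds shown alone.

Among the measured compounds shown here, in a functional assay on HCT-116 cells (Homo sapiens), read by MTT assay, with a stated time of 72 h (a lower number here means a stronger inhibitor, a higher number a weaker inhibitor), compound 2 (`CSc1ncnc2c1c(-c1ccoc1)cn2[C@@H]1O[C@H](CO)[C@@H](O)[C@H]1O`) gives 40 nM and is the only compound here with an exact value. Compound 3 (`CNc1ncnc2c1c(-c1ccoc1)cn2[C@@H]1O[C@H](CO)[C@@H](O)[C@H]1O`) gives > 20000 nM as a limit. Compound 1 (`COc1ncnc2c1c(-c1ccccc1)cn2[C@@H]1O[C@H](CO)[C@@H](O)[C@H]1O`) gives > 20000 nM as a limit too. Compound 3 therefore stands on the limit of > 20000 nM in this assay, at which 2 of the 3 values shown sit, and has no exact place in the series.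

Compound 4 (`CNc1ncnc2c1c(-c1ccccc1)cn2[C@@H]1O[C@H](CO)[C@@H](O)[C@H]1O`) differs from compound 3 by phenyl in place of furan-3-yl on an aromatic carbon. For the measured compounds named here, the only measured step is an at least 500-fold higher number from compound 2 to compound 3 (2.69 log units; beyond the scatter) for methylamino in place of methylsulfanyl, a large change that compound 4 does not undo, as it keeps the methylamino group. Going by the values given here, no measured step covers the exchange of furan-3-yl for phenyl, and compound 1 carries phenyl yet shows no exact value. The expected step is a number no higher from compound 3 to compound 4 (the limit leaves the size open) in this assay with nothing beyond the scatter expected and another limit the likeliest reading. The estimated value for compound 4 is 20000 nM with an expected range from 7000 nM to 40000 nM on this reasoning.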

Compound 4, half-maximal inhibitory concentration: > 20000 nM
Compound 4 ended at the assay's limit (the forecaster's own chance of this, stated with the estimate: 85%); the middle value lies on the limit itself.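

Neither compound 3 and compound 4 nor compound 1 and compound 4 give a readable step, as all three compounds rest on a limit: the limit of > 20000 nM in this assay, at which 3 of the 4 values shown sit. In this assay, going by these compounds, it stays open how phenyl compares with furan-3-yl on the methylamino compounds, and how methylamino compares with methoxy on the phenyl compounds.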